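The source may hold more compounds than are shown below. What is called first, only, known or untested is meant among the compounds shown, and "the series" means these compounds.

Measured so far:
Compound 1 `[N-]=[N+]=NCCCc1ccc(-c2ccc(-c3ccc(-c4cccs4)s3)s2)s1`: > 100000 nM
Compound 2 `BrCCCc1ccc(-c2ccc(-c3ccc(CCCBr)s3)s2)s1`: > 200000 nM

In an ADME assay on MDCK cells (Canis lupus familiaris) for cytotoxicity, read by MTT assay, with a stated time of 2 days (a higher number here means that more compound is tolerated, a lower number that less compound is tolerated), compound 2 gives > 200000 nM, which is a limit and not a number. Going by the values given here, the only other value, for compound 1, is > 100000 nM, and it is a limit too. Compound 3 `BrCCCc1ccc(-c2ccc(-c3ccc(-c4cccs4)s3)s2)s1` has thiophen-2-yl in place of 3-bromopropyl on an aromatic carbon. Among the compounds with values here, no measured step is available as a guide, so the expectation rests on these two limits alone. The expected change, an at least 1.3-fold lower number from compound 2 to compound 3 (0.12 log units; that floor lies within the scatter), is no larger than the usual scatter. Compound 3 is estimated at 150000 nM, with an expected range of 50000 nM to 300000 nM.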

Compound 3, half-maximal cytotoxic concentration: > 200000 nM
Compound 3 ended at the assay's limit (the forecaster's own chance of this, stated with the estimate: 75%); middle value at least 1.3-fold (0.12 log units) away from the limit.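

In this assay, going by these compounds alone, the values of compound 1, compound 2 and compound 3 are all limits, so no step to compound 3 can be read. The compounds shown leave open what concentration of any of them harms these cells.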